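A Methyl Added to an Inactive Amide

The compounds below may be only part of what the source reports. "The series", "measured", "known", "first", "only" and "open" are said of these compounds alone.

In a functional assay on HepG2 cells (Homo sapiens) (on this read-out lower numbers stand for stronger inhibition and higher numbers for weaker inhibition), compound 1 `COc1cccc(OC(C)CNC(C)=O)c1` gives > 1000000 nM, which is a limit of the assay. Compound 2 `CC(=O)NCCOc1ccccc1` gives > 1000000 nM, also a limit. Compound 2 therefore stands at the limit of > 1000000 nM in this assay, at which 2 of the 2 values shown sit. Compound 3 `CC(=O)NCC(C)Oc1ccccc1` differs from compound 2 by methyl in place of hydrogen on a saturated chain carbon bound to an oxygen on an aromatic ring and a saturated chain carbon. In this assay, the expected step of a number no higher from compound 2 to compound 3 (the limit leaves the size open) lies within the usual scatter, with no direction favoured. Compound 3 is estimated at 1000000 nM, with an expected range of 300000 nM to 3000000 nM.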

Compound 3, half-maximal inhibitory concentration: > 1000000 nM
Compound 3 gave a limit, no number (the forecaster's own chance of this, stated with the estimate: 85%); the middle value sits exactly at the limit.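

Compound 3 gives only a limit, as do compound 1 and compound 2, so the steps from compound 1 and compound 2 to compound 3 cannot be read. In this assay the compounds shown leave open how far methyl or methoxy shifts the value.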